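Swapping an Ether for an Aromatic Ring

The source may report more compounds than this note shows. Statements on the series, on what has been measured and on what is new or still open speak of the compounds shown alone.

Going by the values given here, in a functional assay on KARPAS-422 cells (Homo sapiens) for inhibition, with a stated time of 72 h (on this read-out higher numbers stand for weaker inhibition and lower numbers for stronger inhibition), compound 1 (`Cc1cc(C)c(CN2CCc3ccc(O[C@@H]4CCOC4)c(Cl)c3C2=O)c(=O)[nH]1`) gives 512 nM, the lowest of the three numbers so far, though only compound 3 stands clearly apart from it. Compound 2 (`Cc1cc(C)c(CN2CCc3c(F)cc(O[C@@H]4CCOC4)c(Cl)c3C2=O)c(=O)[nH]1`) gives 1030 nM and cannot be separated from compound 1, since the step is a 2.0-fold higher number from compound 1 to compound 2 (0.30 log units; within the scatter). Compound 3 (`Cc1cc(C)c(CN2CCc3c(Cl)cc(-c4cn[nH]c4)c(Cl)c3C2=O)c(=O)[nH]1`) gives 1580 nM, beyond the scatter from compound 1.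

Compound 4 (`Cc1cc(C)c(CN2CCc3ccc(-c4c(C)noc4C)c(Cl)c3C2=O)c(=O)[nH]1`) carries 3,5-dimethyl-1,2-oxazol-4-yl in place of (oxolan-3-yl)oxy on an aromatic carbon. Among the compounds with values here, the one measured step is a fluoro swap elsewhere, so it does not test this change. The nearest guide is compound 3 at 1580 nM, which also has a five-membered aromatic ring instead of the (oxolan-3-yl)oxy group but differs in other places too. That points weakly towards a higher number, and no step beyond the scatter is expected. The estimated step is a 1.6-fold higher number from compound 1 to compound 4 (0.19 log units; within the scatter). For compound 4 the expected value is 800 nM, with an estimated range from 250 nM to 2500 nM.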

Compound 4, half-maximal inhibitory concentration: 121 nM
For compound 4 the middle estimate is 6.6-fold (0.82 log units) above the measured one; the measured number lies below the stated range.
By their numbers in this assay, from the lowest: compound 4; then compounds 1, 2 and 3 (each within the scatter of the next, the first and the last beyond it).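

On the aromatic carbon ortho to a chloro group, (oxolan-3-yl)oxy can give way to 3,5-dimethyl-1,2-oxazol-4-yl, and this assay then shows a 4.2-fold lower number from compound 1 to compound 4 (0.63 log units; beyond the scatter). Going by these compounds alone, this is the only step so far between compounds differing in one place that lies beyond the scatter, and it runs towards stronger inhibition. Inhibition at this position therefore does not depend on an ether link, a non-aromatic ring or a defined stereocentre, and nothing measured here tells why the number falls.

The compounds shown leave open whether the two methyl groups on the new ring are needed, since only the dimethyl form of this ring appears. Also open, going by these compounds, is how a plain phenyl ring or an amine such as morpholine would compare at this carbon.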